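Amide substituent variation on the shared core

The source may hold more compounds than are shown below. What is called first, only, known or untested is meant among the compounds shown, and "the series" means these compounds.

For the measured compounds named here, in a functional assay on HEY cells (Homo sapiens) for cytotoxicity, read by MTT assay, with a stated time of 72 h (on this read-out lower numbers stand for stronger inhibition and higher numbers for weaker inhibition), compound 3 `COc1ccc(CNC(=O)c2nc(Br)c3cccnc3c2N[C@H]2CC[C@H](N)CC2)cc1` gives 4000 nM, the lowest of the three numbers so far. Compound 1 `N[C@H]1CC[C@H](Nc2c(C(=O)NCc3cccc(C(F)(F)F)c3)nc(Br)c3cccnc23)CC1` gives 12000 nM and compound 2 `N[C@H]1CC[C@H](Nc2c(C(=O)NCc3cccs3)nc(Br)c3cccnc23)CC1` gives 11000 nM; the steps of a 3.0-fold lower number from compound 1 to compound 3 (0.48 log units; beyond the scatter) and a 2.8-fold lower number from compound 2 to compound 3 (0.44 log units; beyond the scatter) are modest, while the step of a 1.1-fold lower number from compound 1 to compound 2 (0.04 log units; within the scatter) lies within the scatter. Compound 4 `N[C@H]1CC[C@H](Nc2c(C(=O)NC3CCCCC3)nc(Br)c3cccnc23)CC1` differs from compound 3 by cyclohexyl in place of 4-methoxybenzyl on an amide-type nitrogen. Going by the values given here, no measured step exchanges an aromatic ring for a non-aromatic one, so the two modest gains on reaching compound 3 are the only guide, and the 4-methoxybenzyl group that gave them is removed. Expected is a step of a 2.3-fold higher number from compound 3 to compound 4 (0.35 log units; beyond the scatter), toward a higher number. Compound 4 is estimated at 9000 nM, with a range of 3000 nM to 27000 nM.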

Compound 4, half-maximal inhibitory concentration: 5200 nM
Estimate against measurement, compound 4: 1.7-fold (0.24 log units) above; measured number inside the range.
By their numbers in this assay, from the lowest: compounds 3 and 4 (each within the scatter of the next); then compounds 2 and 1 (each within the scatter of the next).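

In this assay an aromatic ring on the amide-type nitrogen is not needed to hold the lowest numbers: the exchange for cyclohexyl gives a 1.3-fold higher number from compound 3 to compound 4 (0.11 log units; within the scatter) and so keeps level with the 4-methoxybenzyl group. Cyclohexyl also separates from the two other substituents, with a 2.1-fold lower number from compound 2 to compound 4 (0.33 log units; beyond the scatter) and a 2.3-fold lower number from compound 1 to compound 4 (0.36 log units; beyond the scatter) and so the split in this set does not follow aromatic against non-aromatic. No supporting data bear on why these steps take this size.

Open, as far as these compounds go, is how cyclohexylmethyl or an amine on the cyclohexyl ring would read here.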